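The source may report more compounds than this note shows. Statements on the series, on what has been measured and on what is new or still open speak of the compounds shown alone.

Compound 1 `C1=C(c2cncc(Oc3ccccc3)c2)CC2CNCC1C2` is one of two compounds tested in an in vitro assay on SH-EP1 cells for displacement of a labelled ligand from Neuronal acetylcholine receptor; alpha4/beta2 (Homo sapiens); on this read-out higher numbers stand for weaker inhibition and lower numbers for stronger inhibition. In this assay compound 1 gives 0.7 nM, the lower of the two numbers, while compound 2 `C1=C(c2ccc(-c3ccccc3)nc2)CC2CNCC1C2` gives 105 nM, a gap beyond the usual scatter. Compound 3 `COc1cncc(C2=CC3CNCC(C2)C3)c1` has not yet been measured. It differs from compound 1 by methyl in place of phenyl on an oxygen on an aromatic ring. For the measured compounds named here, no measured pair shows this change, so its effect is uncertain; a modest weakening is expected, with a 4.3-fold higher number from compound 1 to compound 3 (0.63 log units; beyond the scatter). For compound 3 the estimated value in this assay is 3 nM, within a range from 0.7 nM to 15 nM.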

Compound 3, inhibition constant: 0.3 nM
The estimate for compound 3 lay 10-fold (1.00 log units) above the measured number, and the stated range ends above it.
By their numbers in this assay, from the lowest: compound 3; then compound 1; then compound 2.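

Phenyl on this oxygen is not needed for strong inhibition: going from phenoxy to methoxy gives a 2.3-fold lower number from compound 1 to compound 3 (0.37 log units; beyond the scatter) in this assay and the stronger inhibition. At this position, a single methyl therefore does better than the larger aromatic ring, so the added ring atoms bring no gain here. No available evidence explains this difference. The compounds shown leave open how an ethyl or a benzyl on the same oxygen would compare, and whether an amine in place of that oxygen would keep this strength.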